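The source may hold more compounds than are shown below. What is called first, only, known or untested is meant among the compounds shown, and "the series" means these compounds.

Measured in a functional assay on HCT-116 cells (Homo sapiens) for antiproliferative activity; a higher number here means a weaker inhibitor, a lower number a stronger inhibitor:
- compound 1 `Cc1c2c(n3c1CCCN[C@@H](C)[C@H](C)Nc1cc-3ccc1C(N)=O)CC(C)(C)CC2=O`: 29 nM
- compound 2 `Cc1c2c(n3c1CCN(C(=O)CN)C[C@@H](C)[C@H](C)Nc1cc-3ccc1C(N)=O)CC(C)(C)CC2=O`: 216 nM

Of the two, compound 2 has the higher number, 216 nM, and compound 1 has the lower number, 29 nM. This gap lies beyond the scatter. Compound 3 `Cc1c2c(n3c1CCN(C(=O)[C@@H](O)C(C)C)C[C@@H](C)[C@H](C)Nc1cc-3ccc1C(N)=O)CC(C)(C)CC2=O` carries 1-hydroxy-2-methylpropyl in place of aminomethyl on a carbonyl carbon. Among the measured compounds shown here, no measured pair shows this change alone, so only a small fall in the number is expected in this assay, within the scatter or close to it. The estimated change is a 1.8-fold lower number from compound 2 to compound 3 (0.26 log units; within the scatter). The expected value for compound 3 is 120 nM, with an estimated range of 35 nM to 400 nM.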

Compound 3, half-maximal inhibitory concentration: 45 nM
Beside the measured number, compound 3's estimate is 2.7-fold (0.43 log units) above it, and the stated range covers the measured number.
By their numbers in this assay, from the lowest: compounds 1 and 3 (each within the scatter of the next); then compound 2.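

In this assay, the group on this carbonyl carbon clearly affects the read-out: 1-hydroxy-2-methylpropyl in place of aminomethyl gives a 4.8-fold lower number from compound 2 to compound 3 (0.68 log units; beyond the scatter). The change adds heavy atoms and a defined stereocentre while keeping one hydrogen-bond donor and one acceptor, so the larger group is tolerated here. Nothing available explains the step.

The compounds shown do not separate the contribution of the hydroxyl from that of the branched carbon chain, nor show the effect of the opposite stereocentre. A 2-methylpropyl group without the hydroxyl, or a longer amine chain, would test this.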